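A few compounds are considered here, and "the series" means these few. Any claim that something is new, unique, unknown or untested is made for them only; others in the source may bear on it.

Within the data shown here, compound 2 `O=C(CCc1ccc(-c2ccccc2F)cc1)N1CCCC1` gives 2800 nM in an assay on HEK293 cells for inhibition of N-acylethanolamine-hydrolyzing acid amidase (Rattus norvegicus), read by LC-MS, with a stated time of 30 min (on this read-out lower numbers stand for stronger inhibition and higher numbers for weaker inhibition), the lowest of the two numbers measured so far. Among the measured compounds shown here, compound 1 `Cc1ccc(-c2ccc(CCC(=O)N3CCCC3)cc2)cc1` gives 33200 nM in this assay, and the only measured step, a 12-fold lower number from compound 1 to compound 2 (1.07 log units; beyond the scatter), is a large one. Compound 3 `O=C(CCc1ccc(-c2cccc(F)c2)cc1)N1CCCC1` differs from compound 2 by 3-fluorophenyl in place of 2-fluorophenyl on an aromatic carbon. For the measured compounds named here, no measured step concerns a move of the fluorine between positions on that ring; the step from compound 1 to compound 2 exchanges a whole substituted phenyl group and so does not bear directly on this change. With nothing shown either way, the expected step is a 1.1-fold higher number from compound 2 to compound 3 (0.03 log units; within the scatter), that is, no change beyond the scatter, and the estimate rests on the value of compound 2, 2800 nM. Compound 3 is therefore expected to give about 3000 nM, with a range from 800 nM to 12000 nM.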

Compound 3, half-maximal inhibitory concentration: 1800 nM
For compound 3 the middle estimate is 1.7-fold (0.22 log units) above the measured one, and the stated range covers the measured number.
By their numbers in this assay, from the lowest: compounds 3 and 2 (each within the scatter of the next); then compound 1.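

In this assay, putting 3-fluorophenyl in place of 2-fluorophenyl gives a 1.6-fold lower number from compound 2 to compound 3 (0.19 log units; within the scatter) and so the two groups cannot be told apart at this place on the shared core. The large step seen with 2-fluorophenyl also appears with the other fluorophenyl group, as 3-fluorophenyl in place of 4-methylphenyl gives an 18-fold lower number from compound 1 to compound 3 (1.27 log units; beyond the scatter) and so both fluorine-bearing compounds lie well apart from compound 1. Nothing given here accounts for either step.

The compounds shown leave open whether the difference from compound 1 follows from removing the methyl group, adding the fluorine or moving the substituent, which an unsubstituted phenyl and a 4-fluorophenyl group would separate. They also leave open how chlorine, methoxy or a carboxylic acid on this ring would read.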